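Working notes: methoxy in place of trifluoromethyl

This account rests on a few compounds, and the source may have more. Where it says the series, first, only, none or still open, it means among the compounds named here.

Measured in an ADME assay on L6 cells (Rattus norvegicus) for cytotoxicity, read by resazurin assay, with a stated time of 70 h; a lower number here means a stronger inhibitor, a higher number a weaker inhibitor:
- compound 1 `CC(=O)Oc1ccc2c(c1)C(C)=CC(C)(C)N2Cc1ccc(C)cc1`: 21000 nM
- compound 2 `CC(=O)Oc1ccc2c(c1)C(C)=CC(C)(C)N2Cc1cccc(Cl)c1`: 29000 nM
- compound 3 `CC(=O)Oc1ccc2c(c1)C(C)=CC(C)(C)N2Cc1cccc(C(F)(F)F)c1`: 27000 nM

Compound 3, at 27000 nM, lies within the scatter of both compound 2 and compound 1, so these three values show no separation. The next structure is compound 4 `COc1cccc(CN2c3ccc(OC(C)=O)cc3C(C)=CC2(C)C)c1`, with methoxy in place of trifluoromethyl on an aromatic carbon; in words, methoxy in place of trifluoromethyl on an aromatic carbon. Going by the values given here, two measured steps bear on it. The closer one, a 1.1-fold lower number from compound 2 to compound 3 (0.03 log units; within the scatter), puts trifluoromethyl in place of chloro on an aromatic carbon. The other, a 1.4-fold higher number from compound 1 to compound 2 (0.14 log units; within the scatter), puts 3-chlorophenyl in place of 4-methylphenyl. Among the compounds with values here, both stay within the scatter, although neither involves methoxy, and no measured compound carries that group. No step beyond the scatter is therefore expected in this assay, and no direction can be assigned. The expected change is a 1.0-fold lower number from compound 3 to compound 4 (0.02 log units; within the scatter), an estimate that stays within the scatter. For compound 4 the estimated value is 26000 nM, with an expected range of 15000 nM to 42000 nM.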

Compound 4, half-maximal inhibitory concentration: 29000 nM
For compound 4 the middle estimate is 1.1-fold (0.05 log units) below the measured one, and the stated range covers the measured number.
By their numbers in this assay, from the lowest: compounds 1, 3, 2 and 4 (each within the scatter of the next).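

In this assay, the aromatic carbon that held chloro and trifluoromethyl now carries methoxy, which has 1 hydrogen-bond acceptor where trifluoromethyl has 0, yet the step stays within the scatter (a 1.1-fold higher number from compound 3 to compound 4 (0.03 log units; within the scatter)). The same holds against chloro (no change at the digits printed from compound 2 to compound 4 (within the scatter)) and against the 4-methylphenyl compound (a 1.4-fold higher number from compound 1 to compound 4 (0.14 log units; within the scatter)). Compounds 2, 3 and 4 therefore show that exchanging chloro, trifluoromethyl and methoxy on this aromatic carbon, now including a group with an oxygen, produces no separation in this measurement.

No measured evidence on the reason for these flat values is available. From the compounds shown here alone, whether an amine, a carboxylic acid or a longer chain on this same aromatic carbon would give a step beyond the scatter remains open.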